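A few compounds are considered here, and "the series" means these few. Any claim that something is new, unique, unknown or untested is made for them only; others in the source may bear on it.

Compound 3 `CS(=O)(=O)NC(=O)CCCc1cn(-c2ccc(Br)cc2)nc1-c1ccc(Cl)cc1` gives 135000 nM in a physicochemical assay for solubility, in phosphate buffer, measured as thermodynamic solubility, at pH 7.4 (on this read-out lower numbers stand for lower solubility and higher numbers for higher solubility), the lower of the two numbers recorded, with compound 1 `CS(=O)(=O)NC(=O)CCc1cn(-c2ccc(Br)cc2)nc1-c1ccc(Cl)cc1` close by at 170000 nM; the gap, a 1.3-fold lower number from compound 1 to compound 3 (0.10 log units; within the scatter), lies within the scatter. Compound 2 `CS(=O)(=O)NCCCc1cn(-c2ccc(Br)cc2)nc1-c1ccc(Cl)cc1` reaches only a limit in this assay, < 5000 nM. The two steps that touch that limit are large: an at least 34-fold lower number from compound 1 to compound 2 (1.53 log units; beyond the scatter) and an at least 27-fold higher number from compound 2 to compound 3 (1.43 log units; beyond the scatter).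

Compound 4 `Clc1ccc(-c2nn(-c3ccc(Br)cc3)cc2CCc2nnn[nH]2)cc1` differs from compound 3 by 1H-tetrazol-5-yl in place of ((methylsulfonyl)carbamoyl)methyl on a saturated chain carbon, two bonds along the chain from an aromatic carbon. Among the measured compounds shown here, no measured step brings in a 1H-tetrazol-5-yl group, so the expectation rests on compound 3 alone, with the chain shortening judged harmless from a 1.3-fold lower number from compound 1 to compound 3 (0.10 log units; within the scatter). Compound 4 is therefore expected to stay in the upper range, estimated at 70000 nM (from 15000 nM to 250000 nM), a step of a 1.9-fold lower number from compound 3 to compound 4 (0.29 log units; within the scatter).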

Compound 4, solubility: 150000 nM
For compound 4 the middle estimate is 2.1-fold (0.33 log units) below the measured one, and the stated range covers the measured number.
By their numbers in this assay, from the lowest: compounds 3, 4 and 1 (each within the scatter of the next). At a limit, below all of these: compound 2.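

In this assay, 1H-tetrazol-5-yl on a saturated chain carbon, two bonds along the chain from an aromatic carbon, matches both compounds carrying a (methylsulfonyl)carbamoyl group: a 1.1-fold higher number from compound 3 to compound 4 (0.05 log units; within the scatter), and a 1.1-fold lower number from compound 1 to compound 4 (0.05 log units; within the scatter). A five-membered aromatic ring thus serves here as well as that open chain group, while the step from the (methanesulfonamido)methyl compound is large: an at least 30-fold higher number from compound 2 to compound 4 (1.47 log units; beyond the scatter). That step is only a bound, as compound 2 stands at a limit: the limit of < 5000 nM in this assay, at which 1 of the 4 values shown sits.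

Going by these compounds, whether a carboxylic acid or an amine at this place, or a longer chain ending in 1H-tetrazol-5-yl, would keep numbers in this range stays open.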